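The compounds below may be only part of what the source reports. "The series", "measured", "known", "first", "only" and "open" are said of these compounds alone.

The measured compounds:

Compound 1, `C/C=C/C(=O)Nc1cccc(-c2nc3ccccc3s2)c1`. In an ADME assay on HepG2 cells (Homo sapiens) for inhibition, with a stated time of 72 h (on this read-out higher numbers stand for an effect only at larger amounts of compound and lower numbers for an effect already at smaller amounts), compound 1 gives > 25000 nM, which is a limit of the assay and not a number.

Compound 2, `O=C(CCl)Nc1cccc(-c2nc3ccccc3s2)c1`. In this assay compound 2 gives 16000 nM.

Compound 2 therefore stands as the only number shown in this assay; the one further value is a limit. On these data alone, the step from compound 1 to compound 2 is an at least 1.5-fold lower number from compound 1 to compound 2 (0.19 log units; that floor lies within the scatter), with chloromethyl in place of prop-1-en-1-yl on a carbonyl carbon, and since compound 1 sits at the limit of > 25000 nM in this assay, at which 1 of the 2 values shown sits, the true size of that step stays open. Compound 3, `CC(Cl)C(=O)Nc1cccc(-c2nc3ccccc3s2)c1`, differs from compound 2 by methyl in place of hydrogen on a saturated chain carbon bound to a carbonyl carbon and a chlorine atom. Among the compounds with values here, no measured step touches this position, and the single measured step has no firm size. Compound 3 is therefore expected to stay close to compound 2 in this assay, with an expected step of a 1.3-fold higher number from compound 2 to compound 3 (0.10 log units; within the scatter) not beyond the scatter. The estimate for compound 3 in this assay is 20000 nM, within 8000 nM to 50000 nM.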

Compound 3, half-maximal effective concentration: > 25000 nM
Compound 3 was reported as a limit; the forecaster's own chance of this, stated with the estimate: 35%; at least 1.2-fold (0.09 log units) between middle value and limit.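

Within the data shown here, no earlier step touched this position, and methyl in place of hydrogen on the saturated chain carbon bound to a carbonyl carbon and a chlorine atom now gives an at least 1.5-fold higher number from compound 2 to compound 3 (0.19 log units; that floor lies within the scatter). In this assay compound 3 gives > 25000 nM, which is a limit of the assay and not a number. The step from compound 1 to compound 3 cannot be read, and the true size of the step from compound 2 stays open, because compound 3 rests on the same limit as compound 1: the limit of > 25000 nM in this assay, at which 2 of the 3 values shown sit.

The compounds shown leave open how far 1-chloroethyl actually lies from chloromethyl in this assay, as only compound 2 carries a number. They also leave open what a longer chain on this carbon, or an amine in place of the chlorine atom, would give.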